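Chain length on the deacetylated glycoside: compound 3 to 4

This account rests on a few compounds, and the source may have more. Where it says the series, first, only, none or still open, it means among the compounds named here.

Measured so far:
compound 1 `CCCCCCCCCCCCCCCCCC(=O)Nc1nnc(S[C@@H]2O[C@H](COC(C)=O)[C@H](OC(C)=O)[C@H](OC(C)=O)[C@H]2OC(C)=O)s1` — 97500 nM
compound 2 `CCCCCCCCCCCCCC(=O)Nc1nnc(S[C@@H]2O[C@H](COC(C)=O)[C@H](OC(C)=O)[C@H](OC(C)=O)[C@H]2OC(C)=O)s1` — 61300 nM
compound 3 `CCCCCCCCCCCC(=O)Nc1nnc(S[C@@H]2O[C@H](CO)[C@H](O)[C@H](O)[C@H]2O)s1` — 8700 nM

All three were run in a functional assay on HeLa cells (Homo sapiens) for cytotoxicity, read by MTT assay, with a stated time of 24 h; a lower number here means a stronger inhibitor, a higher number a weaker inhibitor. Compound 3 stands lowest of the three numbers; compound 2 is nearest to it at a higher number and compound 1 furthest, both gaps beyond the scatter. Compound 3 differs from compounds 1 and 2 in two places at once, the free hydroxyls on the sugar and the shorter chain, so its distance from them cannot be assigned to either change alone.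

Compound 4 `CCCCCCCCCCCCCCCCCC(=O)Nc1nnc(S[C@@H]2O[C@H](CO)[C@H](O)[C@H](O)[C@H]2O)s1` is not yet measured. It differs from compound 3 by hexyl in place of hydrogen on a saturated chain carbon, ten or more bonds along the chain from a carbonyl carbon.

Within the data shown here, one measured step bears on this change: a 1.6-fold lower number from compound 1 to compound 2 (0.20 log units; within the scatter), a change of the same kind on the acetylated pair, which stayed within the scatter. On that basis the chain extension in compound 4 is expected to move the number little, if at all, perhaps slightly upward toward the direction shown by compound 1 against compound 2. The expected step is a 1.4-fold higher number from compound 3 to compound 4 (0.14 log units; within the scatter). Compound 4 is therefore estimated at 12000 nM, with a range from 5000 nM to 30000 nM.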

Compound 4, half-maximal inhibitory concentration: 11200 nM
Compound 4: the middle estimate sits 1.1-fold (0.03 log units) above what was measured; the measured number falls inside the stated range.
By their numbers in this assay, from the lowest: compounds 3 and 4 (each within the scatter of the next); then compounds 2 and 1 (each within the scatter of the next).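

In this assay, on the free-hydroxyl sugar, a 1.3-fold higher number from compound 3 to compound 4 (0.11 log units; within the scatter) puts a second chain-length change within the scatter, after a 1.6-fold lower number from compound 1 to compound 2 (0.20 log units; within the scatter) on the acetylated sugar, so at this saturated chain carbon neither pair shows a readable response to chain length. Compound 4 also carries the same chain as compound 1 and differs from it in having free hydroxyls in place of the acetyl esters on the sugar; compound 1 gives 97500 nM and compound 4 gives 11200 nM, so the distance seen earlier for compound 3 is not a matter of chain length alone. Nothing at hand accounts for the flat response to chain length or for the distance between the sugar forms.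

From the compounds shown here alone, whether the flat response holds for a much shorter chain, such as butyl on the shared core, stays open. Going by these compounds, an amine or a carboxylic acid in place of hexyl at this chain carbon also stays open, since all four compounds carry plain saturated chains.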